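This account rests on a few compounds, and the source may have more. Where it says the series, first, only, none or still open, it means among the compounds named here.

Measured compounds:
- Compound 1, `CCCCCCCCCCCOc1ccccc1CCC(=O)OC[C@H]1OCCC[C@H]1OP(=O)(O)OC[C@H](N)C(=O)O`: 10.6%
- Compound 2, `CCCCCCCCCCCOc1ccccc1CCC(=O)OC[C@H]1OCC=C[C@H]1OP(=O)(O)OC[C@H](N)C(=O)O`: 12.4%

In an assay on HEK293-A cells for agonist activity at putative P2Y purinoceptor 10 (Mus musculus), with a stated time of 1.5 h (on this read-out lower numbers stand for smaller maximal responses and higher numbers for larger maximal responses), compound 2 stands highest of the two numbers, with compound 1 the nearest, a difference that lies within the scatter, so the two show the same weak maximal response. Compound 3, `CCCCCCCCCCCOc1ccccc1CCC(=O)OC[C@H]1OCC=C[C@@H]1OP(=O)(O)OC[C@H](N)C(=O)O`, has not yet been measured. Its difference from compound 2 is the two compounds have the same atoms and bonds; at least one stereo element is drawn with a configuration in one of them and without one in the other: 1 of 4 stereo elements differ; a stereocentre at a saturated ring carbon is drawn R in compound 2 and S in compound 3. Among the measured compounds shown here, no step between two measured compounds is available to guide the size of this change, so the expectation rests on compound 2 alone, with 12.4% as the anchor, and a shift no larger than the scatter seems most likely: a number 1.4 percentage points lower from compound 2 to compound 3 (within the scatter) is the expected step. For compound 3 the estimated result in this assay is 11%, with a likely range from 4% to 22%.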

Compound 3, largest response reached (Emax), in percent of the reference or control that the assay uses: 7.6%
For compound 3 the middle estimate is 3.4 percentage points above the measured one; the range from low to high includes it.
By their numbers in this assay, from the lowest: compounds 3, 1 and 2 (each within the scatter of the next).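

In this assay, among the compounds shown here, the stereocentre at the saturated ring carbon can now be read for the first time: going from R in compound 2 to S in compound 3 gives a number 4.8 percentage points lower from compound 2 to compound 3 (within the scatter) and so shows no clear effect of this configuration on the maximal response. One caution applies to this comparison: the fact that one of compounds 2 and 3 is drawn with a defined configuration and the other without, at the place where they differ.

From the compounds shown here alone, whether the S configuration would behave the same way in the saturated ring of compound 1 remains open. So does the outcome of a carboxylic acid in place of the phosphate.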